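A few compounds are considered here, and "the series" means these few. Any claim that something is new, unique, unknown or untested is made for them only; others in the source may bear on it.

Measured compounds in an ADME assay on Vero cells (Chlorocebus sabaeus) for cytotoxicity, read by sulforhodamine B assay, with a stated time of 48 h; on this read-out higher numbers stand for weaker inhibition of growth and lower numbers for stronger inhibition of growth:

Compound 1, `COc1ccc(/C(Cl)=C/C=C(\C#N)C(=O)c2c[nH]c3ccccc23)cc1`: "not determined" (no result reported).
Compound 2, `COc1ccc(/C(Cl)=C/C=C(\C#N)C(=O)c2c(C)[nH]c3ccccc23)cc1OC`: 41100 nM.
Compound 3, `Cc1[nH]c2ccccc2c1C(=O)/C(C#N)=C/C=C(\Cl)c1ccc(Br)cc1`: "not determined" (no result reported).

Among the measured compounds shown here, compound 2 therefore stands alone on the numbers: it carries the only value in this assay, while compound 1 and compound 3 have no single number against them. For the measured compounds named here, with two of three entries empty, no step between measured compounds can be drawn, and nothing shows how a change on the six-membered aromatic ring of carbon only moves the read-out.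

Compound 4, `COc1cc(/C(Cl)=C/C=C(\C#N)C(=O)c2c(C)[nH]c3ccccc23)cc(OC)c1OC`, is the next member awaiting measurement in this assay. It differs from compound 2 in one place: methoxy in place of hydrogen on an aromatic carbon. The change is small in what it counts, a methoxy group entering for a hydrogen on an aromatic carbon that already sits ortho to one methoxy group and meta to another.

Lacking any comparable step, the expectation is conservative. The step of a 1.1-fold lower number from compound 2 to compound 4 (0.03 log units; within the scatter) is expected to stay within the usual scatter, with no direction claimed beyond it. On that basis compound 4 is expected to give about 38000 nM in this assay, with a range from 15000 nM to 90000 nM.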

Compound 4, concentration for total growth inhibition: 42600 nM
Beside the measured number, compound 4's estimate is 1.1-fold (0.05 log units) below it, and the stated range covers the measured number.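

In this assay, the step of a 1.0-fold higher number from compound 2 to compound 4 (0.02 log units; within the scatter) gives the series its first readable comparison, and that step lies within the scatter. For this one pair, then, methoxy in place of hydrogen on an aromatic carbon, ortho to a methoxy group and meta to another methoxy group, gives two values that cannot be told apart, so this position accepts the added group without a measurable difference on this read-out. No measurement at hand speaks to why the read-out behaves this way.

The compounds shown leave open whether a different group on this aromatic carbon, such as an amine or a carboxylic acid, would separate from compound 2 in this assay. Also open, from the compounds shown here alone, is whether a longer chain in place of the methoxy group, or a change elsewhere on the shared core, would produce a step beyond the scatter, as a single pair sets no pattern for the series.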